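This account rests on a few compounds, and the source may have more. Where it says the series, first, only, none or still open, it means among the compounds named here.

Measured in a functional assay on DU-145 cells (Homo sapiens) for cytotoxicity, read by MTT assay, with a stated time of 72 h; on this read-out lower numbers stand for stronger inhibition and higher numbers for weaker inhibition:

compound 1 `COc1ccc(C(=O)c2cc(OC)c(OC)c(OC)c2)cc1NC(=O)/C=C/c1cc(OC)c(OC)c(OC)c1` — compound 1 gives 6300 nM
compound 2 `COc1ccc(C(=O)c2cc(OC)c(OC)c(OC)c2)cc1NC(=O)/C=C/c1ccc(OC)c(OC)c1` — compound 2 gives 10200 nM
compound 3 `COc1ccc(/C=C/C(=O)Nc2cc(C(=O)c3cc(OC)c(OC)c(OC)c3)ccc2OC)cc1` — compound 3 gives 12800 nM

Among these three numbers compound 2 stands second highest: its nearest neighbour is compound 3, reached by a 1.3-fold higher number from compound 2 to compound 3 (0.10 log units; within the scatter), and its furthest is compound 1, from which it is separated by a 1.6-fold higher number from compound 1 to compound 2 (0.21 log units; within the scatter). Compound 4 `COc1cc(/C=C/C(=O)Nc2cc(C(=O)c3cc(OC)c(OC)c(OC)c3)ccc2OC)ccc1F` is the next case, differing from compound 2 by fluoro in place of methoxy on an aromatic carbon. Among the compounds with values here, no measured pair swaps a methoxy for a fluoro on that ring, so the step must be judged indirectly. The two steps that bear on it each remove a methoxy from that same ring, a 1.6-fold higher number from compound 1 to compound 2 (0.21 log units; within the scatter) and a 1.3-fold higher number from compound 2 to compound 3 (0.10 log units; within the scatter), both within the scatter; only the larger change a 2.0-fold higher number from compound 1 to compound 3 (0.31 log units; beyond the scatter) reaches a modest size. Compound 4 is therefore expected to show no step beyond the scatter in this assay, with an estimated 1.2-fold higher number from compound 2 to compound 4 (0.07 log units; within the scatter). The estimate for compound 4 is 12000 nM, with a range from 5000 nM to 30000 nM.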

Compound 4, half-maximal inhibitory concentration: 12100 nM
Estimate against measurement, compound 4: 1.0-fold (0.00 log units) below; measured number inside the range.
By their numbers in this assay, from the lowest: compounds 1, 2, 4 and 3 (each within the scatter of the next, the first and the last beyond it).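

In this assay, within the data shown here, compounds 1, 2 and 3 all carry methoxy on the aromatic carbon para to a large group, so compound 4 gives the first reading of a change at this carbon: a 1.2-fold higher number from compound 2 to compound 4 (0.07 log units; within the scatter). Compound 4 also stays within the scatter of the 4-methoxyphenyl compound, with a 1.1-fold lower number from compound 3 to compound 4 (0.02 log units; within the scatter), so exchanging methoxy for fluoro here gives no separable change in this set. Against the 3,4,5-trimethoxyphenyl compound, the reading is a 1.9-fold higher number from compound 1 to compound 4 (0.28 log units; within the scatter), which remains within the scatter, while the step of a 2.0-fold higher number from compound 1 to compound 3 (0.31 log units; beyond the scatter) lies just beyond it.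

No measured evidence is available to explain these numbers. From the compounds shown here alone, it remains open whether an amine, a hydroxyl or a longer chain on this carbon would also leave the number within the scatter of compound 2.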